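The source may report more compounds than this note shows. Statements on the series, on what has been measured and on what is new or still open speak of the compounds shown alone.

Measured in a functional assay on SH-SY5Y cells (Homo sapiens) for antiproliferative activity, read by MTT assay, with a stated time of 48 h; on this read-out lower numbers stand for stronger inhibition of growth and higher numbers for weaker inhibition of growth:
compound 1 `COc1ccc(N(C)c2ncnc3c2ncn3Cc2ccc(OC)c(OC)c2)cc1` gives 430 nM.
Compound 2 `COc1ccc(N(C)c2ncnc3c2ncn3Cc2cc(OC)cc(OC)c2)cc1` gives only a limit of the assay, > 100000 nM.
Compound 3 `COc1ccc(Cn2cnc3c(Cl)ncnc32)cc1OC` gives only a limit of the assay, > 100000 nM.

The two cores differ as 3,5-dimethoxyphenyl in place of 3,4-dimethoxyphenyl on a saturated chain carbon bound to an aromatic nitrogen, and this change gives an at least 230-fold higher number from compound 1 to compound 2 (2.36 log units; beyond the scatter). The change chloro in place of (4-methoxyphenyl)(methyl)amino on an aromatic carbon gives an at least 230-fold higher number from compound 1 to compound 3 (2.36 log units; beyond the scatter); both steps end at a limit because of the limit of > 100000 nM in this assay, at which 2 of the 3 values shown sit.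

Compound 4 `COc1cc(Cn2cnc3c(Cl)ncnc32)cc(OC)c1` is not yet measured. It differs from compound 2 by chloro in place of (4-methoxyphenyl)(methyl)amino on an aromatic carbon, the same change already seen from compound 1 to compound 3, and it carries both changes that each reached the limit. With compound 2 already at the limit, the step from it is expected to be about a number no higher from compound 2 to compound 4 (the limit leaves the size open). Compound 4 is therefore expected to give 100000 nM in this assay, most likely again only a limit.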

Compound 4, concentration for 50% growth inhibition: > 100000 nM
Compound 4 gave a limit, no number (the forecaster's own chance of this, stated with the estimate: 90%); the middle value sits exactly at the limit.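

In this assay compound 4 gives only a limit, > 100000 nM. No step from compound 2 to compound 4 can be read, because both end at a limit: the limit of > 100000 nM in this assay, at which 3 of the 4 values shown sit.

The compounds shown leave open the actual values of compound 2, compound 3 and compound 4.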